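A few compounds are considered here, and "the series" means these few. Any claim that something is new, unique, unknown or untested is made for them only; others in the source may bear on it.

Three compounds have been measured in a functional assay on A-375 cells (Homo sapiens) for cytotoxicity, read by MTT assay, with a stated time of 72 h, tested at 3 uM; on this read-out lower numbers stand for less inhibition of growth and higher numbers for more inhibition of growth at the one concentration tested:

compound 1 `N/C(=N\NC(=S)N1CCOCC1)c1ccccn1`, 19.3%
compound 2 `N/C(=N\NC(=S)N1CCCCC1)c1ccccn1`, 86.5%
compound 3 `Cc1cccc(/C(N)=N/NC(=S)N2CCOCC2)n1`, 34.7%

Compound 1 stands lowest of the three. The exchange on the thiocarbonyl carbon gave a number 67.2 percentage points higher from compound 1 to compound 2 (beyond the scatter), a large step, while the substitution on the aromatic ring gave a number 15.4 percentage points higher from compound 1 to compound 3 (beyond the scatter), a modest one. Compound 4 `N/C(=N\NC(=S)N1CCOCC1)c1ccc(F)cn1` differs from compound 1 by fluoro in place of hydrogen on an aromatic carbon. Within the data shown here, only the step from compound 1 to compound 3 bears on this change, since it too alters the aromatic ring; the exchange at the thiocarbonyl carbon is not touched here. A modest rise, or none beyond the scatter, is therefore expected, a number 8.7 percentage points higher from compound 1 to compound 4 (within the scatter). Compound 4 is estimated at 28%, in the range 12% to 48%.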

Compound 4, percent growth inhibition at one concentration: 66.4%
The estimate for compound 4 lay 38.4 percentage points below the measured number, and the stated range ends below it.
By their numbers in this assay, from the lowest: compound 1; then compound 3; then compound 4; then compound 2.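

In this assay, a single fluoro on an aromatic carbon, two atoms from the ring nitrogen and para to a large group, gives a number 47.1 percentage points higher from compound 1 to compound 4 (beyond the scatter), with morpholin-4-yl kept on the thiocarbonyl carbon. So a change on the ring alone can produce a large step, whereas the methyl step, a number 15.4 percentage points higher from compound 1 to compound 3 (beyond the scatter), was only modest. No measurement shown here accounts for this rise. From the compounds shown here alone, it remains open whether chloro or methoxy at this position would act like fluoro, and whether fluoro would add anything to the piperidin-1-yl of compound 2.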